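Sulfonyl aryl changes in a fluoroquinolinyl series

A few compounds are considered here, and "the series" means these few. Any claim that something is new, unique, unknown or untested is made for them only; others in the source may bear on it.

Measured so far:
compound 1 `O=S(=O)(c1ccc(F)c(Cl)c1)c1cnc2c(F)cccc2c1-c1ccc(Cl)cc1`: 0.01 mL/min
compound 2 `O=S(=O)(c1cc(F)cc(F)c1)c1cnc2c(F)cccc2c1-c1ccc(Cl)cc1`: 0.73 mL/min
compound 3 `Cc1ccc(S(=O)(=O)c2cnc3c(F)cccc3c2-c2ccc(Cl)cc2)cc1F`: 2.2 mL/min

In an ADME assay on microsomes from liver (Homo sapiens) for metabolic stability, tested at 2.5 uM (a higher number here means faster removal of the compound, a lower number slower removal), compound 3 gives the highest of the three numbers. The nearest is compound 2, with a 3.0-fold higher number from compound 2 to compound 3 (0.48 log units; beyond the scatter); the furthest is compound 1, with a 220-fold higher number from compound 1 to compound 3 (2.34 log units; beyond the scatter). Compound 4 `N#Cc1cccc(S(=O)(=O)c2cnc3c(F)cccc3c2-c2ccc(Cl)cc2)c1` differs from compound 3 by 3-cyanophenyl in place of 3-fluoro-4-methylphenyl on a sulfonyl sulfur. Both measured steps at this position bear on the change, and both were beyond the scatter, one of them large. For the measured compounds named here, no measured compound carries a 3-cyanophenyl, so the direction is not fixed by the data. Compound 4 is expected to show a 2.2-fold lower number from compound 3 to compound 4 (0.34 log units; beyond the scatter), and its value is estimated at 1 mL/min, within a range from 0.2 mL/min to 4 mL/min.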

Compound 4, intrinsic clearance in a liver preparation (reported as CLH), per the amount of preparation that the assay uses: 0.08 mL/min
For compound 4 the middle estimate is 13-fold (1.10 log units) above the measured one; measured number below the stated range.
By their numbers in this assay, from the lowest: compound 1; then compound 4; then compound 2; then compound 3.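

In this assay, the 3-cyanophenyl group on the sulfonyl sulfur gives a 28-fold lower number from compound 3 to compound 4 (1.44 log units; beyond the scatter) and a 9.1-fold lower number from compound 2 to compound 4 (0.96 log units; beyond the scatter), but still an 8.0-fold higher number from compound 1 to compound 4 (0.90 log units; beyond the scatter). A nitrile-bearing aryl group thus moves this number beyond the scatter, and the 3-chloro-4-fluorophenyl of compound 1 keeps the lowest number of the four. Nothing available accounts for these steps. The compounds shown leave open how a carboxylic acid or an amine on this phenyl ring would compare, and whether a nitrile combined with a chlorine would bring the number lower still.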